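The source may report more compounds than this note shows. Statements on the series, on what has been measured and on what is new or still open speak of the compounds shown alone.

Compound 2 `Cc1nc(C)c([C@H](OC(C)(C)C)C(=O)O)c(N2CCC(C)(C)CC2)c1-c1ccc(OCCc2ccc(C#N)cc2)cc1` shares its core with compound 1 `Cc1nc(C)c([C@H](OC(C)(C)C)C(=O)O)c(N2CCC(C)(C)CC2)c1-c1ccc(-c2ccccc2)cc1`. In a toxicity assay on MT2 cells (Homo sapiens) for cytotoxicity, read by XTT assay, with a stated time of 4 days (on this read-out higher numbers stand for lower toxicity in this test and lower numbers for higher toxicity in this test), compound 2 gives only a limit, >= 33500 nM. In this assay compound 1 likewise gives a limit, >= 20000 nM. The step that the two limits leave unreadable from compound 1 to compound 2 is therefore unreadable, both values sitting at limits (the limit of >= 20000 nM in this assay, at which 1 of the 2 values shown sits; (the limit of >= 33500 nM in this assay, at which 1 of the 2 values shown sits)). Compound 3 `Cc1nc(C)c([C@H](OC(C)(C)C)C(=O)O)c(N2CCC(C)(C)CC2)c1-c1ccc(OCCc2ccc(F)c(F)c2)cc1` differs from compound 2 by 3,4-difluorophenyl in place of 4-cyanophenyl on a saturated chain carbon, two bonds along the chain from an oxygen on an aromatic ring. Within the data shown here, no measured step bears on this change, so no shift beyond the scatter is expected, a number no higher from compound 2 to compound 3 (the limit leaves the size open). Compound 3 is expected to sit at or near the limit again, estimated at 33500 nM with a range from 20000 nM to 60000 nM.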

Compound 3, half-maximal cytotoxic concentration: >= 33500 nM
Compound 3: only a limit was reported; the forecaster's own chance of this, stated with the estimate: 85%; the middle value sits exactly at the limit.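

In this assay, among these compounds, compound 1, compound 2 and compound 3 all give only limits, so no step among them can be read. On these data alone, the concentration at which any of the three becomes cytotoxic remains open, as does any effect of 3,4-difluorophenyl in place of 4-cyanophenyl.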